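This account rests on a few compounds, and the source may have more. Where it says the series, first, only, none or still open, it means among the compounds named here.

Measured compounds:
compound 1 `Nc1ccccc1Cn1cc(CCCCC[C@@H]2SC[C@@H]3NC(=O)N[C@@H]32)nn1`: > 16000 nM
compound 2 `O=C1N[C@H]2[C@H](CS[C@H]2CCCCCc2cn(Cc3ccc(C(F)(F)F)cc3)nn2)N1`: > 16000 nM
compound 3 `O=C1N[C@H]2[C@H](CS[C@H]2CCCCCc2cn(Cc3ccc(I)cc3)nn2)N1`: > 16000 nM

All three share one core and differ only in the benzyl group attached to the ring nitrogen. In an assay on isolated protein for inhibition of biotin--protein ligase (Homo sapiens), read by scintillation counting, with a stated time of 10 min (a lower number here means a stronger inhibitor, a higher number a weaker inhibitor), compound 1 reaches only a limit of the assay, > 16000 nM, so no number is known for it. Compound 2 likewise stands at a limit, > 16000 nM. Compound 3 stands at a limit too, > 16000 nM. Because every value sits at the limit of > 16000 nM in this assay, at which 3 of the 3 values shown sit, the steps a step that the two limits leave unreadable from compound 1 to compound 2, a step that the two limits leave unreadable from compound 1 to compound 3 and a step that the two limits leave unreadable from compound 2 to compound 3 cannot be read in size or in direction. Compound 4 `O=C1N[C@H]2[C@H](CS[C@H]2CCCCCc2cn(Cc3ccccc3F)nn2)N1` differs from compound 1 by fluoro in place of amino on an aromatic carbon. The measured steps bear on this change only in showing that swapping one aryl substituent for another has not brought any compound to a readable number. Compound 4 is therefore expected to remain at the limit as well, a step that the limit leaves unreadable from compound 1 to compound 4 whose size would then stay unreadable. The estimate for compound 4 is 30000 nM, with a range from 8000 nM to 150000 nM.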

Compound 4, inhibition constant: > 16000 nM
Compound 4: only a limit was reported; the forecaster's own chance of this, stated with the estimate: 85%; the middle value lies beyond the limit too.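

No step between compound 4 and compound 1, compound 2 or compound 3 can be read in this assay, because all four compounds give only a limit of the assay: the limit of > 16000 nM in this assay, at which 4 of the 4 values shown sit.

The compounds shown leave open how strongly any of the four actually inhibits, and whether the benzyl group changes that at all.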